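The compounds below may be only part of what the source reports. "The series", "measured", "known", "first", "only" and "open" are said of these compounds alone.

Compound 1 `C[C@H]1CC(Cl)=C([Si](C)(C)C)[C@@H](C2CCCCC2)O1` is the starting point. In a functional assay on A2780 cells (Homo sapiens) for antiproliferative activity (on this read-out higher numbers stand for weaker inhibition of growth and lower numbers for stronger inhibition of growth), compound 1 gives 32000 nM, the lowest number among the three compounds measured, although compound 2 sits within the scatter of it. Compound 2 `C[Si](C)(C)C1=C(Cl)C[C@H](C2CCCCC2)O[C@@H]1C1CCCCC1` gives 46000 nM in this assay, and compound 3 `C[Si](C)(C)C1=C(Cl)C[C@H](Cc2ccccc2)O[C@@H]1C1CCCCC1` gives 78000 nM. The step of a 1.4-fold higher number from compound 1 to compound 2 (0.16 log units; within the scatter) stays within the scatter, the step of a 2.4-fold higher number from compound 1 to compound 3 (0.39 log units; beyond the scatter) is a modest weakening, and the step of a 1.7-fold higher number from compound 2 to compound 3 (0.23 log units; within the scatter) again stays within the scatter.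

Compound 4 `C[C@@H]1O[C@H](C2CCCCC2)C([Si](C)(C)C)=C(Cl)[C@H]1C` differs from compound 1 by methyl in place of hydrogen on a saturated ring carbon. Within the data shown here, none of the measured steps touches this place on the ring: the known changes swap groups on other carbons of the shared core, and each of them moved the number only a little, if at all. A single added methyl is a smaller change than any of those, so the expectation is for no shift beyond the scatter, with perhaps a slight weakening if the pattern of the measured steps carries over. The estimate for compound 4 is 40000 nM, within the range 15000 nM to 110000 nM, which corresponds to an expected step of a 1.3-fold higher number from compound 1 to compound 4 (0.10 log units; within the scatter).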

Compound 4, concentration for total growth inhibition: 38000 nM
Estimate against measurement, compound 4: 1.1-fold (0.02 log units) above; measured number inside the range.
By their numbers in this assay, from the lowest: compounds 1, 4, 2 and 3 (each within the scatter of the next, the first and the last beyond it).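

Compound 4 is the first of the compounds shown to carry a change on this saturated ring carbon, which lies next to the ring atom that bears a chloro group and next to the ring atom that bears a methyl group. The earlier steps shown here all concerned other carbons of the shared core, so they gave no reading for this place. In this assay, the step of a 1.2-fold higher number from compound 1 to compound 4 (0.07 log units; within the scatter) shows that a single methyl in place of hydrogen here produces no difference that can be told from the scatter, and no supporting data are available to explain this result.

Among these compounds, this reading covers only one small group in one spatial arrangement, so it remains open whether the methyl pointing the opposite way would give the same result. Going by these compounds, it also remains open whether a longer chain such as propyl, a hydroxyl, an amine or a carboxylic acid on this carbon would leave the number just as close to that of compound 1, or would move it beyond the scatter.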